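The source may report more compounds than this note shows. Statements on the series, on what has been measured and on what is new or still open speak of the compounds shown alone.

Working notes on the series. Compound 1 `COc1cc(-c2nc(C(c3ccc(F)cc3)c3ccc(F)cc3)sc2CC(=O)O)ccn1`, compound 2 `O=C(O)Cc1sc(CS(=O)(=O)c2ccc(Cl)cc2)nc1-c1ccc(Cl)cc1` and compound 3 `N#Cc1ccc(-c2nc(C(c3ccc(F)cc3)c3ccc(F)cc3)sc2CC(=O)O)cc1` share one core. In an in vitro functional assay on HEK285-7 cells for antagonist activity at prostaglandin D2 receptor 2 (Homo sapiens), read by BRET and beta-arrestin recruitment (a lower number here means a smaller maximal response, a higher number a larger maximal response), compound 1 gives 60%, compound 2 gives 30%, and compound 3 gives 30%. Compound 3 thus stands level with compound 2, the two together the lowest of the three numbers, with compound 1 the furthest away. Going by the values given here, the only measured single-point step is a number 30 percentage points lower from compound 1 to compound 3 (beyond the scatter), where 4-cyanophenyl replaced 2-methoxypyridin-4-yl. Compound 4 `O=C(O)Cc1sc(C(c2ccc(F)cc2)c2ccc(F)cc2)nc1-c1ccnc(F)c1` carries 2-fluoropyridin-4-yl in place of 4-cyanophenyl on an aromatic carbon. That measured step bears directly here: the 4-cyanophenyl that entered there now leaves, and the entering 2-fluoropyridin-4-yl shares its ring with the 2-methoxypyridin-4-yl of compound 1, so a partial reversal is expected in this assay. Compound 4 is estimated at 45%, range 25% to 70%. The expected step of a number 15 percentage points higher from compound 3 to compound 4 (beyond the scatter) points upward, its size uncertain since methoxy and fluorine differ.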

Compound 4, largest response reached (reported as efficacy), in percent of the reference or control that the assay uses: 80%
Compound 4: middle estimate off by 35 percentage points, on the low side; the measured number lies above the stated range.
By their numbers in this assay, from the lowest: compounds 2 and 3 (each within the scatter of the next); then compound 1; then compound 4.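

At this position in this assay the aryl group can lift the number past that of compound 1 and not merely restore it, with a number 50 percentage points higher from compound 3 to compound 4 (beyond the scatter) on going from 4-cyanophenyl to 2-fluoropyridin-4-yl. With the ring kept, its substituent alone also moves the read-out, with a number 20 percentage points higher from compound 1 to compound 4 (beyond the scatter) for fluoro in place of methoxy. Nothing at hand explains either step.

As far as these compounds go, whether fluoro is unusual on this ring stays open, and a chloro group or an amine in its place would test that. Also open, from the compounds shown here alone, is how 2-fluoropyridin-4-yl behaves on the core of compound 2.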